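Replacing the Aryl Sulfonamide with a Methylimidazole

The compounds below may be only part of what the source reports. "The series", "measured", "known", "first", "only" and "open" are said of these compounds alone.

Three compounds share one core and differ only in the group attached to the sulfonyl sulfur. Compound 1 `COc1ccc(-c2cccc(S(=O)(=O)N3CCC(N4CCC(C)CC4)CC3)c2)cc1` gives 23 nM in a functional assay on DLD-1 cells (Homo sapiens) for antiproliferative activity, read by CellTiter-Glo, with a stated time of 72 h; on this read-out lower numbers stand for stronger inhibition and higher numbers for weaker inhibition. Compound 2 `Cc1cccc(S(=O)(=O)N2CCC(N3CCC(C)CC3)CC2)c1` gives 25 nM in this assay and so stands highest of the three numbers, although the step of a 1.1-fold higher number from compound 1 to compound 2 (0.04 log units; within the scatter) lies within the scatter. Compound 3 `CC1CCN(C2CCN(S(=O)(=O)c3cccc(-c4ccccc4C(F)(F)F)c3)CC2)CC1` gives 10 nM in this assay, and the step of a 2.5-fold lower number from compound 2 to compound 3 (0.40 log units; beyond the scatter) is modest but beyond the scatter.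

Compound 4 `CC1CCN(C2CCN(S(=O)(=O)c3cn(C)cn3)CC2)CC1` is not yet measured. It differs from compound 2 by 1-methyl-1H-imidazol-4-yl in place of 3-methylphenyl on a sulfonyl sulfur. Going by the values given here, the measured steps each exchange one group on the six-membered aromatic ring of carbon only and move the number by no more than the step of a 2.5-fold lower number from compound 2 to compound 3 (0.40 log units; beyond the scatter). None of them removes that ring itself, so they bear on this change only loosely and the expectation is uncertain. A weakening step of a 6.0-fold higher number from compound 2 to compound 4 (0.78 log units; beyond the scatter) is expected. Compound 4 is estimated to give 150 nM in this assay, with a range from 30 nM to 800 nM.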

Compound 4, half-maximal inhibitory concentration: > 5000 nM
Compound 4: no number, only a limit; the forecaster's own chance of this, stated with the estimate: 10%; middle value at least 33-fold (1.52 log units) away from the limit.
By their numbers in this assay, from the lowest: compound 3; then compounds 1 and 2 (each within the scatter of the next). At a limit, above all of these: compound 4.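

In this assay, the result for compound 4 is a limit of the assay and not a number: the limit of > 5000 nM in this assay, at which 1 of the 4 values shown sits. The change still gives an at least 200-fold higher number from compound 2 to compound 4 (2.30 log units; beyond the scatter), far more than any step among compounds 1, 2 and 3. Going by these compounds alone, those three all keep the six-membered aromatic ring of carbon only on the sulfonyl sulfur and vary only what it carries, so this is the first sign that activity depends on that ring itself, and that 1-methyl-1H-imidazol-4-yl cannot stand in for 3-methylphenyl at this place.

The single change alters ring size and adds two nitrogen atoms at once, so the compounds shown cannot tell which of these accounts for the loss. They also leave open how a pyridine or a thiophene ring would behave on the sulfonyl sulfur.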